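The source may report more compounds than this note shows. Statements on the series, on what has been measured and on what is new or still open speak of the compounds shown alone.

Measured so far:
- compound 1, `CCNc1nc(/C=C/c2ccc(OC)c(OC)c2)cc(/C=C/c2ccc(OC)c(OC)c2)n1`: 38500 nM in a functional assay on HT-29 cells (Homo sapiens) for inhibition, read by resazurin assay, with a stated time of 48 h; a higher number here means a weaker inhibitor, a lower number a stronger inhibitor
- compound 2, `COc1ccc(/C=C/c2cc(/C=C/c3ccc(OC)c(OC)c3)nc(NCCO)n2)cc1OC`: 7100 nM

Compound 2 holds the lowest of the two numbers; its nearest neighbour is compound 1, and the step of a 5.4-fold lower number from compound 1 to compound 2 (0.73 log units; beyond the scatter) lies beyond the scatter. Compound 3, `CCCNc1nc(/C=C/c2ccc(OC)c(OC)c2)cc(/C=C/c2ccc(OC)c(OC)c2)n1`, is not yet measured. It differs from compound 2 by methyl in place of hydroxy on a saturated chain carbon, two bonds along the chain from a nitrogen on an aromatic ring. For the measured compounds named here, only one measured step bears on this: the hydroxy that entered a 5.4-fold lower number from compound 1 to compound 2 (0.73 log units; beyond the scatter) is the group that now leaves, so compound 3 differs from compound 1 only by a methyl added to the chain. The expectation is therefore a return toward compound 1, a higher number than compound 2, and the estimated step is a 4.2-fold higher number from compound 2 to compound 3 (0.63 log units; beyond the scatter). Whether the extra methyl shifts the number on its own cannot be judged from two compounds. Compound 3 is estimated at 30000 nM, in the range 12000 nM to 75000 nM.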

Compound 3, half-maximal inhibitory concentration: > 100000 nM
Compound 3: a limit, no number; the forecaster's own chance of this, stated with the estimate: 10%; middle value at least 3.3-fold (0.52 log units) from the limit.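

In this assay compound 3 gives a limit and not a number: the limit of > 100000 nM in this assay, at which 1 of the 3 values shown sits. Exchanging 2-hydroxyethyl for propyl produces an at least 14-fold higher number from compound 2 to compound 3 (1.14 log units; beyond the scatter), a larger move than the one seen when the hydroxy was first introduced on the ethyl chain. The added methyl also counts on its own, with an at least 2.5-fold higher number from compound 1 to compound 3 (0.41 log units; beyond the scatter), so this position responds to the methyl as well as to the hydroxy, and both moves raise the number.

From the compounds shown here alone, with a limit at one end, the full size of both steps stays unknown. A 2-methoxyethyl or 2-aminoethyl chain, or a longer chain ending in hydroxy, would show whether the lower number of compound 2 depends on the hydroxy itself or would also hold for other groups at this place.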